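The source may report more compounds than this note shows. Statements on the series, on what has been measured and on what is new or still open speak of the compounds shown alone.

Working notes on the series. Compound 1 `O=C(Nc1ccc(Cl)cc1)NS(=O)(=O)c1ccc(Cl)s1` and compound 2 `CSc1ccc(S(=O)(=O)NC(=O)Nc2ccc(Cl)cc2)s1` share one core and differ in a single group on an aromatic carbon. Among the measured compounds shown here, in a functional assay on the whole organism (6C3HED cells, Mus musculus) for inhibition, at a dose of 300 mg/kg by the oral route (on this read-out lower numbers stand for less inhibition and higher numbers for more inhibition at the one dose given (going by the name of the read-out)), compound 1 gives 89%, and compound 2 gives 62%, the lowest of the two numbers; the one measured step, a number 27 percentage points lower from compound 1 to compound 2 (beyond the scatter), is a modest drop beyond the scatter. Compound 3 `CCc1ccc(S(=O)(=O)NC(=O)Nc2ccc(Cl)cc2)[nH]1` is not yet measured; it differs from compound 2 by 5-ethyl-1H-pyrrol-2-yl in place of 5-(methylsulfanyl)thiophen-2-yl on a sulfonyl sulfur, the change sitting on the sulfonyl sulfur whose other neighbour is the amide-type nitrogen. The step from compound 1 to compound 2 bears only loosely on this change, since it altered one group on the ring rather than the ring itself, and it was modest. The expected step of a number 7 percentage points lower from compound 2 to compound 3 (within the scatter) is therefore within the scatter, with wide uncertainty. For compound 3 the estimate in this assay is 55%, ranging from 20% to 85%.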

Compound 3, a percentage reported as inhibition, in the whole organism at one dose (the size of the read-out at that dose, not a potency): 56%
The estimate for compound 3 lay 1 percentage points below the measured number; low and high end bracket the measured number.
By their numbers in this assay, from the lowest: compounds 3 and 2 (each within the scatter of the next); then compound 1.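

In this assay the change on the sulfonyl sulfur from 5-(methylsulfanyl)thiophen-2-yl to 5-ethyl-1H-pyrrol-2-yl gives a number 6 percentage points lower from compound 2 to compound 3 (within the scatter) and so replaces the ring itself, bringing in a hydrogen-bond donor, without a shift that can be told from the scatter. Set against 5-chlorothiophen-2-yl, the same 5-ethyl-1H-pyrrol-2-yl group gives a number 33 percentage points lower from compound 1 to compound 3 (beyond the scatter) and thus a large step, so of the three groups at this place only the one in compound 1 stands apart. Nothing at hand accounts for either step.

The compounds shown do not separate the ring from the group it carries, so a chloro group on the pyrrole ring remains an open case. Equally open, going by these compounds, is how a carboxylic acid or an amine in place of the ethyl group would read in this assay.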